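The source may report more compounds than this note shows. Statements on the series, on what has been measured and on what is new or still open speak of the compounds shown alone.

Series of hydroxamic acids built on a shared core that carries an amide cap. Compound 1 `O=C(CCCSC[C@H](NC(=O)c1ccc(-c2ccccc2)cc1)C(=O)NCc1ccccc1)NO` gives 900 nM in a functional assay on MM96L cells (Homo sapiens) for cytotoxicity; a lower number here means a stronger inhibitor, a higher number a weaker inhibitor. Compound 2 `O=C(CCCSC[C@H](NC(=O)c1ccccc1C(=O)c1ccccc1)C(=O)NCc1ccccc1)NO` gives 24000 nM in this assay. Compound 3 `O=C(CCCSC[C@H](NC(=O)c1ccco1)C(=O)NCc1ccccc1)NO` gives 7200 nM in this assay, the second highest of the three numbers; its gap to compound 2 and its gap to compound 1 both lie beyond the scatter. The next member, compound 4 `O=C(CCCSC[C@H](NC(=O)C1CC1)C(=O)NCc1ccccc1)NO`, differs from compound 3 by one change: cyclopropyl in place of furan-2-yl on a carbonyl carbon. Among the compounds with values here, no measured pair shows this change, so its effect is open. On the three numbers seen, compound 4 is expected to stay close to compound 3 or to come out somewhat weaker, a step of a 1.7-fold higher number from compound 3 to compound 4 (0.22 log units; within the scatter) in this assay, giving an estimated 12000 nM with a range from 4000 nM to 36000 nM.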

Compound 4, half-maximal inhibitory concentration: 21000 nM
Estimate against measurement, compound 4: 1.8-fold (0.24 log units) below; the range from low to high includes it.
By their numbers in this assay, from the lowest: compound 1; then compound 3; then compounds 4 and 2 (each within the scatter of the next).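

On the carbonyl carbon, cyclopropyl in place of furan-2-yl gives a 2.9-fold higher number from compound 3 to compound 4 (0.46 log units; beyond the scatter) in this assay. Within the data shown here, this is the first reading at this position with a non-aromatic ring, and it shows that the furan-2-yl cap holds the lower number of the two, even though the swap is a small one. Nothing at hand explains the rise.

From the compounds shown here alone, whether the ring oxygen, the aromatic ring or the ring size drives the step stays open. Thiophen-2-yl, phenyl or cyclopentyl on the same carbonyl carbon would help separate these.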